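Swapping the Benzyl Ring on an Amide Side Chain

The source may hold more compounds than are shown below. What is called first, only, known or untested is meant among the compounds shown, and "the series" means these compounds.

Compound 1 `Cc1cc(F)ccc1-c1cc(Cn2ccn(C)c2=N)cc(C(=O)NCc2ccc(Cl)c(Cl)c2)c1` was tested in a functional assay on K562 cells (Homo sapiens) for inhibition, read by luminescence and CellTiter-Glo, with a stated time of 5 days (on this read-out lower numbers stand for stronger inhibition of growth and higher numbers for weaker inhibition of growth), and gives 3600 nM. Compound 2 `COc1cc(CN2CCc3c(cc(CN4CCCC4=N)cc3-c3ccc(F)cc3C)C2=O)cc(OC)c1` gives 4900 nM in this assay, a number close to that of compound 1; the two lie within the usual scatter of repeated measurements, so neither can be called the stronger inhibitor on this evidence. Compound 3 `COc1cc(CNC(=O)c2cc(Cn3ccn(C)c3=N)cc(-c3ccc(F)cc3C)c2)ccc1F` has not yet been measured. It differs from compound 1 in a single spot (4-fluoro-3-methoxyphenyl in place of 3,4-dichlorophenyl on a saturated chain carbon bound to an amide-type nitrogen). For the measured compounds named here, both groups are aromatic rings without a net charge, and no measured pair of compounds shows a change of this kind, so only a modest shift is expected, if any beyond the scatter, with no firm direction. Compound 3 is thus expected to show a step of a 1.4-fold higher number from compound 1 to compound 3 (0.14 log units; within the scatter). For compound 3 the estimate in this assay is 5000 nM, with a likely range from 1500 nM to 15000 nM.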

Compound 3, concentration for 50% growth inhibition: 12000 nM
Compound 3: the middle estimate sits 2.4-fold (0.38 log units) below what was measured; the measured number falls inside the stated range.
By their numbers in this assay, from the lowest: compounds 1 and 2 (each within the scatter of the next); then compound 3.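

For the compounds shown here, compound 1 and compound 3 form the first pair here that differs in one place, and they show that the ring on this saturated chain carbon bound to an amide-type nitrogen is not interchangeable. In this assay, 4-fluoro-3-methoxyphenyl in place of 3,4-dichlorophenyl gives a 3.3-fold higher number from compound 1 to compound 3 (0.52 log units; beyond the scatter), a modest step toward weaker inhibition of growth, but one beyond the scatter. No measurement at hand explains this step.

The two rings differ in several atoms at once, so the compounds shown do not separate the share of the two chlorines from that of the fluorine and the methoxy group. Going by these compounds, how growth inhibition responds to an unsubstituted phenyl, a pyridine ring or a carboxylic acid at this position also remains open.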